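Methyl for methoxy: a second instance in the series

This account rests on a few compounds, and the source may have more. Where it says the series, first, only, none or still open, it means among the compounds named here.

Compound 1 `COc1ccc(N2COc3ccc(C(=O)/C=C/c4ccccc4O)cc3C2)cc1` and compound 2 `COc1ccc(N2COc3ccc(C(=O)/C=C/c4cc(OC)c(OC)c(OC)c4)cc3C2)cc1` share a core; the difference between the two cores is not broken down here. In a functional assay on the whole organism (strain Wistar) for inhibition, with Rattus norvegicus as the target, read by paw edema, with a stated time of 3 h, at a dose of 20 mg/kg by the oral route (a lower number here means less inhibition, a higher number more inhibition at the dose given (going by the name of the read-out)), compound 1 gives 55.7%, and compound 2 gives 62.2%, a number within the scatter of compound 1 and beyond the scatter only against compound 3. Compound 3 `Cc1ccc(N2COc3ccc(C(=O)/C=C/c4ccccc4O)cc3C2)cc1` differs from compound 1 by methyl in place of methoxy on an aromatic carbon and in this assay compound 3 gives 51%; the step is a number 4.7 percentage points lower from compound 1 to compound 3 (within the scatter). Compound 4 `COc1cc(/C=C/C(=O)c2ccc3c(c2)CN(c2ccc(C)cc2)CO3)cc(OC)c1OC` carries the same change on compound 2: methyl in place of methoxy on an aromatic carbon. Among the measured compounds shown here, the one measured instance of this change moved the read-out little, so a step of similar size is expected from compound 2 to compound 4, a number 4.7 percentage points lower from compound 2 to compound 4 (within the scatter), resting on a number 4.7 percentage points lower from compound 1 to compound 3 (within the scatter). Compound 4 is therefore estimated at 57.5% in this assay, expected between 48% and 67%.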

Compound 4, a percentage reported as inhibition, in the whole organism at one dose (the size of the read-out at that dose, not a potency): 56.5%
For compound 4 the middle estimate is 1 percentage points above the measured one; the measured number falls inside the stated range.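

In this assay the second instance of methyl in place of methoxy, 4-methoxyphenyl to 4-methylphenyl, reads a number 5.7 percentage points lower from compound 2 to compound 4 (within the scatter). On these two cores the change carries over with steps that do not differ: the same change on two cores in this assay, a number 4.7 percentage points lower (within the scatter) from compound 1 to compound 3 and a number 5.7 percentage points lower (within the scatter) from compound 2 to compound 4, 1 percentage points apart, within the scatter of two such steps. Among the compounds shown here, this shows only that the swap leaves the read-out within the scatter on both cores; with two pairs, a single dose and a single time point, it does not show that the step transfers to other cores or that it would hold at other doses.

The compounds shown carry only methoxy and methyl at this place on the ring. On these data alone, an amine, a carboxylic acid, chlorine or a longer chain there remains open.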